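A Morpholine Cap in Place of Methoxymethyl

A few compounds are considered here, and "the series" means these few. Any claim that something is new, unique, unknown or untested is made for them only; others in the source may bear on it.

Compound 1, `CN1CCN(S(=O)(=O)c2ccc(NC(=O)c3ccccc3)c3ccccc23)CC1`, gives in an assay on L1.2 cells for binding affinity to C-C chemokine receptor type 8 (Homo sapiens) (a higher number here means a weaker inhibitor, a lower number a stronger inhibitor), only the limit > 30000 nM.
Compound 2, `CCOC(=O)N1CCC(NS(=O)(=O)c2ccc(OC(=O)c3ccccc3)c3ccccc23)CC1`, gives in this assay a value of 16.4 nM.
Compound 3, `COCC(=O)N1CCC(NS(=O)(=O)c2ccc(NC(=O)c3ccccc3C)c3ccccc23)CC1`, gives in this assay a value of 15.8 nM.

Compound 3 holds the lowest of the two numbers shown, but compound 2 sits so close that the two cannot be told apart within the usual scatter. Compound 1 reached only the limit of the assay, as recorded in the limit of > 30000 nM in this assay, at which 1 of the 3 values shown sits.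

Compound 4, `Cc1ccccc1C(=O)Nc1ccc(S(=O)(=O)NC2CCN(C(=O)N3CCOCC3)CC2)c2ccccc12`, has not yet been measured. It differs from compound 3 in one place: morpholin-4-yl in place of methoxymethyl on a carbonyl carbon. Going by the values given here, no measured pair shows exactly this change. What is known is that compound 2 and compound 3 carry different groups on the same amide-type nitrogen in a ring and still give values within the scatter of each other. On that basis the step from compound 3 to compound 4 is expected to be small, not beyond the scatter, at a 1.3-fold higher number from compound 3 to compound 4 (0.10 log units; within the scatter). Compound 4 is therefore estimated at 20 nM in this assay, with a likely range from 6 nM to 70 nM.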

Compound 4, inhibition constant: 6.3 nM
The estimate for compound 4 lay 3.2-fold (0.50 log units) above the measured number; the range from low to high includes it.
By their numbers in this assay, from the lowest: compound 4; then compounds 3 and 2 (each within the scatter of the next). At a limit, above all of these: compound 1.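

In this assay, going by these compounds alone, placing morpholin-4-yl on the carbonyl carbon in place of methoxymethyl gives a 2.5-fold lower number from compound 3 to compound 4 (0.40 log units; beyond the scatter) and gives the first reading of a change at this place alone. Within the data shown here, no earlier pair of compounds differs only here, so this step is the first sign that the group on this carbonyl carbon can shift the number. It also shows that the position accepts a ring of 6 heavy atoms in place of a chain of 3 with no loss in this assay, though nothing measured here accounts for the size of the step.

On these data alone, it remains open whether the ring oxygen of morpholin-4-yl matters, which piperidin-1-yl on the same carbonyl carbon would test. Also open, as far as these compounds go, is how an open-chain dimethylamino group or a 4-methylpiperazin-1-yl ring would compare.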